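The source may report more compounds than this note shows. Statements on the series, on what has been measured and on what is new or still open speak of the compounds shown alone.

Of the compounds shown here, three sharing one core have been tested in a functional assay on MCF7 cells (Homo sapiens) for antiproliferative activity, read by CCK-8 assay, with a stated time of 72 h; a lower number here means a stronger inhibitor, a higher number a weaker inhibitor. Compound 1 `CCOc1cc(C(C)(C)C)ccc1C1=NC(c2ccc(Cl)cc2)C(c2ccc(Cl)cc2)N1C(=O)N1CCN(Cc2ccc(C(=O)NO)cc2)CC1` gives 3970 nM. Compound 2 `CCOc1cc(C(C)(C)C)ccc1C1=NC(c2ccc(Cl)cc2)C(c2ccc(Cl)cc2)N1C(=O)NCCCCC(=O)Nc1ccccc1N` gives 29100 nM. Compound 3 `CCOc1cc(C(C)(C)C)ccc1C1=NC(c2ccc(Cl)cc2)C(c2ccc(Cl)cc2)N1C(=O)NCCCCCCCC(=O)NO` gives 7920 nM, which places compound 3 second highest of the three numbers: compound 1 sits within the scatter of it, while compound 2 lies beyond it on the high side.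

Compound 4 `CCOc1cc(C(C)(C)C)ccc1C1=NC(c2ccc(Cl)cc2)C(c2ccc(Cl)cc2)N1C(=O)NCCCCCCC(=O)Nc1ccccc1N` differs from compound 3 in one place: (2-aminophenyl)carbamoyl in place of (hydroxycarbamoyl)methyl on a saturated chain carbon, six bonds along the chain from an amide-type nitrogen. Going by the values given here, the only measured step that bears on this is a 3.7-fold lower number from compound 2 to compound 3 (0.57 log units; beyond the scatter), in which the chain end carrying a (2-aminophenyl)carbamoyl group gave way to one carrying a (hydroxycarbamoyl) group and the number dropped modestly. Going from compound 3 to compound 4 brings the (2-aminophenyl)carbamoyl end back, so a step of similar size in the opposite direction, toward a higher number, is expected in this assay, on the order of a 3.2-fold higher number from compound 3 to compound 4 (0.50 log units; beyond the scatter). Compound 4 is therefore estimated at 25000 nM, with a range from 9000 nM to 70000 nM.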

Compound 4, half-maximal inhibitory concentration: > 100000 nM
Compound 4: no number, only a limit (the forecaster's own chance of this, stated with the estimate: 10%); at least 4.0-fold (0.60 log units) between middle value and limit.
By their numbers in this assay, from the lowest: compounds 1 and 3 (each within the scatter of the next); then compound 2. At a limit, above all of these: compound 4.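

In this assay compound 4 gives no number, only a limit of the assay: the limit of > 100000 nM in this assay, at which 1 of the 4 values shown sits. Going by these compounds alone, at this chain position, placing (2-aminophenyl)carbamoyl where (hydroxycarbamoyl)methyl stood is a large loss, with an at least 12-fold higher number from compound 3 to compound 4 (1.10 log units; beyond the scatter), a step larger than the modest one the earlier compounds showed. Keeping the (2-aminophenyl)carbamoyl end and changing only the chain also loses activity, with an at least 3.4-fold higher number from compound 2 to compound 4 (0.53 log units; beyond the scatter), so the longer chain brings no gain for this end group.

Because compound 4 is a limit, the true size of both steps stays unknown, and the compounds shown do not say why the activity falls. As far as these compounds go, it also remains open how a carboxylic acid or a primary amide would behave at this chain end, and whether a still shorter chain would help the (2-aminophenyl)carbamoyl compounds.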